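Methoxy on the phenylpiperazine: two cores, one kind of change

The source may report more compounds than this note shows. Statements on the series, on what has been measured and on what is new or still open speak of the compounds shown alone.

Compound 1 `Cc1ccc(-c2nnc(N3CCN(C(=O)CN4CCN(c5ccccc5)CC4)CC3)nc2-c2ccc(C)cc2)cc1` and compound 2 `COc1ccc(N2CCN(CC(=O)N3CCN(c4nnc(-c5ccc(C)cc5)c(-c5ccc(C)cc5)n4)CC3)CC2)cc1` share a core and differ only by methoxy in place of hydrogen on an aromatic carbon. In an ADME assay on NIH3T3 cells (Mus musculus) for cytotoxicity, read by MTT assay, with a stated time of 24 h (a lower number here means a stronger inhibitor, a higher number a weaker inhibitor), compound 1 reaches only a limit of the assay, > 914000 nM. In this assay compound 2 gives 116000 nM. The step is an at least 7.8-fold lower number from compound 1 to compound 2 (0.89 log units; beyond the scatter); its size is known only as a lower bound because compound 1 sits at the limit of > 914000 nM in this assay, at which 1 of the 3 values shown sits.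

Compound 3 `O=C(CN1CCN(c2ccccc2)CC1)N1CCN(c2nnc(-c3ccc(Cl)cc3)c(-c3ccc(Cl)cc3)n2)CC1` carries a different core; the difference between the two cores is not broken down here. In this assay compound 3 also reaches only a limit, > 850000 nM. Compound 4 `COc1ccccc1N1CCN(CC(=O)N2CCN(c3nnc(-c4ccc(Cl)cc4)c(-c4ccc(Cl)cc4)n3)CC2)CC1` differs from compound 3 by methoxy in place of hydrogen on an aromatic carbon. Going by the values given here, this is the same kind of change as the one from compound 1 to compound 2, though not the same: there the methoxy sits para to a large group, here ortho to a large group.

Resting on the step from compound 1 to compound 2, compound 4 is expected to give a lower number than compound 3, with an estimated step of an at least 3.4-fold lower number from compound 3 to compound 4 (0.53 log units; beyond the scatter). The estimate for compound 4 is 250000 nM, between 80000 nM and 900000 nM.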

Compound 4, half-maximal inhibitory concentration: 405000 nM
The estimate for compound 4 lay 1.6-fold (0.21 log units) below the measured number; measured number inside the range.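

Methoxy in place of hydrogen again gives a lower number in this assay, with an at least 2.0-fold lower number from compound 3 to compound 4 (0.32 log units; beyond the scatter), so on these two cores the change runs the same way. Set side by side, the two steps compare as follows: the same change on two cores in this assay, an at least 7.8-fold lower number (0.89 log units; beyond the scatter) from compound 1 to compound 2 and an at least 2.0-fold lower number (0.32 log units; beyond the scatter) from compound 3 to compound 4; the limit leaves it open whether they differ. Each step starts from a limit of the assay, so the pair shows a shared direction but not whether the size of the step carries from one core to the other, and the methoxy does not sit in the same place in the two cases, being ortho to a large group in compound 4.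

The compounds shown leave open how far the result depends on the place of the methoxy, since neither core is shown with the group in both places. They also leave open whether the step belongs to methoxy in particular, or whether a hydroxyl, an amine or a longer ether chain on the same ring would give a similar step.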